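A Phenyl Swap Among Esters Stuck at a Limit

The source may report more compounds than this note shows. Statements on the series, on what has been measured and on what is new or still open speak of the compounds shown alone.

In a functional assay on B16 cells (Mus musculus) for inhibition (a higher number here means a weaker inhibitor, a lower number a stronger inhibitor), compound 1 `COc1ccc2oc(=O)cc(COC(=O)C=C(C)C)c2c1` gives only a limit, > 10 ug/mL. Compound 2 `C=CC(=O)OCc1cc(=O)oc2cc(OC)c(OC)cc12` also gives only a limit, > 10 ug/mL. Compound 3 `C/C=C/C(=O)OCc1cc(=O)oc2cc(OC)c(OC)cc12` likewise gives only a limit, > 10 ug/mL. This places compound 3 at the limit of > 10 ug/mL in this assay, at which 3 of the 3 values shown sit.

Compound 4 `COc1cc2oc(=O)cc(COC(=O)/C=C/c3ccccc3)c2cc1OC` differs from compound 3 by phenyl in place of methyl on a double-bonded chain carbon bound to a double-bonded chain carbon, with phenyl in place of methyl on a double-bonded chain carbon bound to a double-bonded chain carbon. Among the compounds with values here, the only measured step, a step that the two limits leave unreadable from compound 2 to compound 3, has no readable size. Nothing therefore supports a shift in either direction, and none beyond the scatter is expected. The estimated step in this assay is a step that the limit leaves unreadable from compound 3 to compound 4. For compound 4 the expected value is 15 ug/mL, with an estimated range of 5 ug/mL to 50 ug/mL.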

Compound 4, half-maximal inhibitory concentration: > 10 ug/mL
Compound 4 was reported as a limit; the forecaster's own chance of this, stated with the estimate: 75%; the middle value is on the limit's open side.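

Compound 4 is also only a limit, so the steps to it from compound 2 and compound 3 cannot be read: the limit of > 10 ug/mL in this assay, at which 4 of the 4 values shown sit.

The compounds shown leave open how strongly any of these esters inhibits in this assay, and whether 2-phenylethenyl and prop-1-en-1-yl differ at all.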